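Five-membered heteroaryl exchange on the shared core

The compounds below may be only part of what the source reports. "The series", "measured", "known", "first", "only" and "open" are said of these compounds alone.

Of the compounds shown here, two have been measured in an assay on CHO cells for displacement of a labelled ligand from Substance-P receptor (Homo sapiens), in the presence of a further agent that is not named here; a lower number here means a stronger inhibitor, a higher number a weaker inhibitor. Compound 1 `C[C@@H](O[C@H]1CN2C(=O)C=C(c3ccc(CO)cc3)CC2[C@@H]1c1ccc(F)cc1)c1cc(C(F)(F)F)cc(C(F)(F)F)c1` carries a 4-(hydroxymethyl)phenyl group on a double-bonded ring carbon of the shared core, and in this assay compound 1 gives 23 nM. Compound 2 `C[C@@H](O[C@H]1CN2C(=O)C=C(c3cnn(C)c3)CC2[C@@H]1c1ccc(F)cc1)c1cc(C(F)(F)F)cc(C(F)(F)F)c1` carries 1-methyl-1H-pyrazol-4-yl at that place, and in this assay compound 2 gives 5.4 nM, the lower of the two numbers. Within the data shown here, the step of a 4.3-fold lower number from compound 1 to compound 2 (0.63 log units; beyond the scatter) is the only measured step, and it is the one that bears on the present change, since it alters the same position.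

Compound 3 `CCc1noc(C2=CC(=O)N3C[C@H](O[C@H](C)c4cc(C(F)(F)F)cc(C(F)(F)F)c4)[C@@H](c4ccc(F)cc4)C3C2)n1` is not yet measured. It differs from compound 2 by 3-ethyl-1,2,4-oxadiazol-5-yl in place of 1-methyl-1H-pyrazol-4-yl on a double-bonded ring carbon. Among the measured compounds shown here, the single measured step shows that exchanging the group at this place can shift the number by a modest amount, but it compares two other groups, so neither direction nor size for the oxadiazolyl is fixed by the data. A step no larger than that one is expected, most likely within the scatter, so a 1.5-fold higher number from compound 2 to compound 3 (0.17 log units; within the scatter) is the expected change. For compound 3 the estimate in this assay is 8 nM, with a range from 3 nM to 25 nM.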

Compound 3, half-maximal inhibitory concentration: 27 nM
For compound 3 the middle estimate is 3.4-fold (0.53 log units) below the measured one, and the stated range ends below it.
By their numbers in this assay, from the lowest: compound 2; then compounds 1 and 3 (each within the scatter of the next).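

Notes on the position: in this assay the step of a 5.0-fold higher number from compound 2 to compound 3 (0.70 log units; beyond the scatter) shows that the lower number of compound 2 does not follow from having a five-membered aromatic ring at this double-bonded ring carbon, since both groups in this pair have one, and the exchange of one such ring for the other is enough to lose the gain seen earlier. The step of a 1.2-fold higher number from compound 1 to compound 3 (0.07 log units; within the scatter) lies within the scatter, so 3-ethyl-1,2,4-oxadiazol-5-yl and 4-(hydroxymethyl)phenyl cannot be told apart here, and among the three compounds only the 1-methyl-1H-pyrazol-4-yl group stands apart from the others. No measurement at hand accounts for any of these steps.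

The change from compound 2 to compound 3 alters the ring and its alkyl group together, so the compounds shown cannot assign the step to the ring or to the ethyl chain, a question that 3-methyl-1,2,4-oxadiazol-5-yl or 1-ethyl-1H-pyrazol-4-yl would address. Also open, from the compounds shown here alone, is how this position responds to a group of another kind, such as an amine or a carboxylic acid on the same carbon.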